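This account rests on a few compounds, and the source may have more. Where it says the series, first, only, none or still open, it means among the compounds named here.

Measured compounds in a functional assay on Jurkat cells for inhibition of nuclear factor NF-kappa-B complex (Homo sapiens); on this read-out higher numbers stand for weaker inhibition and lower numbers for stronger inhibition:
compound 1 `CCOC(=O)c1cnc(CC)nc1NN1C(=O)C=C(C)C1=O`, 10000 nM
compound 2 `CCOC(=O)c1cnc(-c2csc(C)n2)nc1NN1C(=O)C=C(C)C1=O`, 8000 nM
compound 3 `CCOC(=O)c1cnc(-c2cccc(OC)c2)nc1NN1C(=O)C=C(C)C1=O`, 5000 nM

Compound 3 sits at the low end of these three numbers, but its separation from the other two is small: a 2.0-fold lower number from compound 1 to compound 3 (0.30 log units; within the scatter) and a 1.6-fold lower number from compound 2 to compound 3 (0.20 log units; within the scatter) both stay within the scatter, as does a 1.3-fold lower number from compound 1 to compound 2 (0.10 log units; within the scatter). Across the three, exchanging the group on the aromatic carbon of the shared core from ethyl to 2-methyl-1,3-thiazol-4-yl to 3-methoxyphenyl moves this assay by no more than the repeat scatter.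

Compound 4 `CCOC(=O)c1cnc(-c2cccc(Br)c2)nc1NN1C(=O)C=C(C)C1=O` has not yet been measured. It differs from compound 3 by bromo in place of methoxy on an aromatic carbon. Going by the values given here, no measured step exchanges one substituent of the 3-methoxyphenyl group for another; the steps that come nearest, a 2.0-fold lower number from compound 1 to compound 3 (0.30 log units; within the scatter) and a 1.6-fold lower number from compound 2 to compound 3 (0.20 log units; within the scatter), replace the whole group at that carbon and are within the scatter. Nothing therefore points to a step beyond the scatter in this assay for this change. Compound 4 is expected to give 5000 nM, between 2000 nM and 15000 nM, the estimated step being no change at the digits printed from compound 3 to compound 4 (within the scatter).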

Compound 4, half-maximal inhibitory concentration: 700 nM
For compound 4 the middle estimate is 7.1-fold (0.85 log units) above the measured one, and the stated range ends above it.
By their numbers in this assay, from the lowest: compound 4; then compounds 3, 2 and 1 (each within the scatter of the next).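

Exchanging only the substituent on the aryl group, 3-methoxyphenyl to 3-bromophenyl, shifts this assay beyond the scatter (a 7.1-fold lower number from compound 3 to compound 4 (0.85 log units; beyond the scatter)), which the replacements of the whole group among ethyl, 2-methyl-1,3-thiazol-4-yl and 3-methoxyphenyl did not do. The 3-bromophenyl group also stands clear of the other two groups (an 11-fold lower number from compound 2 to compound 4 (1.06 log units; beyond the scatter); a 14-fold lower number from compound 1 to compound 4 (1.15 log units; beyond the scatter)), so this position can respond in this assay, and compound 4 is the only one of the four set apart from the rest. No measurement available bears on what underlies this step.

As far as these compounds go, whether the step is particular to bromo remains open, since chloro, iodo, an amine or a carboxylic acid on the same aromatic carbon could give a different number. Also open, from the compounds shown here alone, is whether the bromo step holds when the ethyl ester of the shared core is exchanged for an amide.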